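Biaryl replacement next to the ring nitrogen: compound 3

A few compounds are considered here, and "the series" means these few. Any claim that something is new, unique, unknown or untested is made for them only; others in the source may bear on it.

Compound 2 `Cc1cc(-c2nc(C(F)(F)F)ccc2CNC(=O)C(C)c2ccc(NS(C)(=O)=O)c(F)c2)ccc1F` gives 0.4 nM in an assay on CHO cells for antagonist activity at transient receptor potential cation channel subfamily V member 1 (Homo sapiens), read by FLIPR (a higher number here means a weaker inhibitor, a lower number a stronger inhibitor), the lowest of the two numbers available; the nearest is compound 1 `CC(C(=O)NCc1ccc(C(F)(F)F)nc1-c1ccccc1F)c1ccc(NS(C)(=O)=O)c(F)c1`, which in this assay gives 63.3 nM. For the measured compounds named here, the only measured step, a 160-fold lower number from compound 1 to compound 2 (2.20 log units; beyond the scatter), puts 4-fluoro-3-methylphenyl in place of 2-fluorophenyl on an aromatic carbon and is large. Compound 3 `CC(C(=O)NCc1ccc(C(F)(F)F)nc1-c1ccc(Cl)c(Cl)c1)c1ccc(NS(C)(=O)=O)c(F)c1` carries 3,4-dichlorophenyl in place of 4-fluoro-3-methylphenyl on an aromatic carbon: a 3,4-dichlorophenyl in place of the 4-fluoro-3-methylphenyl, on the aromatic carbon next to the ring nitrogen, ortho to a large group and meta to the trifluoromethyl group. Going by the values given here, the measured step bears on this change only loosely: it shows that the substituents on this phenyl ring matter a great deal, but no step compares two groups that differ only in the kind of substituent while keeping the same pattern. Compound 3 keeps the pattern of compound 2 rather than that of compound 1. The expected step in this assay is therefore a 2.5-fold higher number from compound 2 to compound 3 (0.40 log units; beyond the scatter), small if any and toward a somewhat higher number. Compound 3 is estimated at 1 nM, with a range from 0.2 nM to 6 nM.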

Compound 3, inhibition constant: 0.9 nM
Compound 3: middle estimate off by 1.1-fold (0.05 log units), on the high side; low and high end bracket the measured number.
By their numbers in this assay, from the lowest: compound 2; then compound 3; then compound 1.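

In this assay the move from 4-fluoro-3-methylphenyl to 3,4-dichlorophenyl on this aromatic carbon gives a 2.3-fold higher number from compound 2 to compound 3 (0.35 log units; beyond the scatter) and is thus a modest change, small beside the gap that both rings hold to the 2-fluorophenyl of compound 1. Compound 3 keeps most of that gap, with a 70-fold lower number from compound 1 to compound 3 (1.85 log units; beyond the scatter) on the same shared core, so the low numbers at this position do not depend on keeping the methyl group or the fluorine: two chlorines in their place still give a number far below that of compound 1. The data on hand hold no measurement that could explain either step.

Whether one substituent alone would carry the gain remains open, since a phenyl bearing a single chlorine or a single methyl group is not among the compounds shown, and neither is a ring bearing a methoxy group or a nitrile. For the compounds shown here, with only three compounds, all varied at this one position, nothing shows whether the same ranking of these rings would hold if the trifluoromethyl group or the methanesulfonamide were replaced.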